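Two Aryl Groups Compared on a Shared Core

The source may report more compounds than this note shows. Statements on the series, on what has been measured and on what is new or still open speak of the compounds shown alone.

Measured compounds:
compound 1, `CC1=C(O)CC(Cc2cccc3c2CCC(NS(=O)(=O)c2ccc(Cl)cc2)C3)C1=O`, 11.2 nM
compound 2, `O=C1C(c2ccc(F)cc2)=C(O)CC1Cc1cccc2c1CCC(NS(=O)(=O)c1ccc(Cl)cc1)C2`, 6.5 nM

Both were tested in a functional assay on HEK293-A cells for antagonist activity at thromboxane A2 receptor (Homo sapiens), read by HTRF and inositol phosphate accumulation, with a stated time of 60 min; on this read-out lower numbers stand for stronger inhibition and higher numbers for weaker inhibition. Of the two numbers, that of compound 2 is the smaller, yet the step of a 1.7-fold lower number from compound 1 to compound 2 (0.24 log units; within the scatter) lies within the scatter, so the two compounds cannot be separated on these data. Compound 3, `Cc1cccc(C)c1C1=C(O)CC(Cc2cccc3c2CCC(NS(=O)(=O)c2ccc(Cl)cc2)C3)C1=O`, has not been measured yet. It differs from compound 2 by 2,6-dimethylphenyl in place of 4-fluorophenyl on a double-bonded ring carbon. Among the measured compounds shown here, the only measured step, from methyl to an aryl group, was small; no measured pair compares two different aryl groups at this position, so there is no direct guide. Since the step of a 1.7-fold lower number from compound 1 to compound 2 (0.24 log units; within the scatter) stayed within the scatter, the expectation is for no step beyond the scatter in this assay for compound 3. Compound 3 is therefore estimated at 8 nM, with a range from 3 nM to 25 nM. The expected step is a 1.2-fold higher number from compound 2 to compound 3 (0.09 log units; within the scatter).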

Compound 3, half-maximal inhibitory concentration: 0.015 nM
For compound 3 the middle estimate is 530-fold (2.73 log units) above the measured one, and the stated range ends above it.
By their numbers in this assay, from the lowest: compound 3; then compounds 2 and 1 (each within the scatter of the next).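

At this position the choice of aryl group matters far more than the two earlier compounds suggested: on the shared core, replacing 4-fluorophenyl with 2,6-dimethylphenyl gives a 430-fold lower number from compound 2 to compound 3 (2.64 log units; beyond the scatter) in this assay even though the two groups are close in size by heavy-atom count. Replacing methyl with 2,6-dimethylphenyl gives a 750-fold lower number from compound 1 to compound 3 (2.87 log units; beyond the scatter) in the same assay, whereas compound 2 also carries an aryl group and cannot be separated from compound 1, so having an aryl group here does not by itself bring the large step. Nothing available here explains why this exchange has so large an effect. The compounds shown do not tell whether both methyl groups are needed, as a comparison with 2-methylphenyl or plain phenyl would show. They also leave open whether other groups on the ring, such as those in 2,6-dichlorophenyl or 2,6-dimethoxyphenyl, would match 2,6-dimethylphenyl.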